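The source may report more compounds than this note shows. Statements on the series, on what has been measured and on what is new or still open speak of the compounds shown alone.

Of the compounds shown here, two built on one shared core have been tested so far, compound 1 `C=CC/N=C1\S/C(=C\c2ccc(OC)cc2)C(=O)N1C` and compound 2 `COc1ccc(/C=C2\S/C(=N\c3ccc(C(C)(C)C)cc3)N(C)C2=O)cc1`. In a functional assay on MCF7 cells (Homo sapiens) for antiproliferative activity, read by MTT assay, with a stated time of 72 h (a higher number here means a weaker inhibitor, a lower number a stronger inhibitor), compound 1 gives > 100000 nM, which is a limit of the assay and not a number. In this assay, compound 2 gives > 100000 nM, which is also a limit. Compound 2 therefore has no exact number, and the evidence so far comes down to the limit of > 100000 nM in this assay, at which 2 of the 2 values shown sit.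

Compound 3 `COc1ccc(/C=C2\S/C(=N\c3ccc(Br)cc3)N(C)C2=O)cc1` has bromo in place of tert-butyl on an aromatic carbon, para to a large group: bromo in place of tert-butyl on an aromatic carbon. Going by the values given here, no measured pair shows what this kind of swap does. In this assay, the expectation is a small step towards a stronger inhibitor, and possibly none beyond the scatter. The only anchor for that expectation is compound 2, with its limit of > 100000 nM. The estimated change is an at least 1.2-fold lower number from compound 2 to compound 3 (0.09 log units; that floor lies within the scatter). Compound 3 is expected to remain a weak inhibitor, with an estimated value of 80000 nM. The expected range for compound 3 runs from 20000 nM to 150000 nM.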

Compound 3, half-maximal inhibitory concentration: > 100000 nM
Compound 3: no number, only a limit; the forecaster's own chance of this, stated with the estimate: 60%; middle value at least 1.2-fold (0.09 log units) from the limit.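

Neither the step from compound 2 to compound 3 nor the step from compound 1 to compound 3 can be read, as no compound here has an exact number: the limit of > 100000 nM in this assay, at which 3 of the 3 values shown sit.

The compounds shown leave open whether any change to the shared core can give a measurable value in this assay.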